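This account rests on a few compounds, and the source may have more. Where it says the series, first, only, none or still open, it means among the compounds named here.

Compound 1, `C=CCOc1ccccc1C1CC(=O)c2ccccc2O1`, in a functional assay on J774.A1 cells (Mus musculus) for inhibition, read by immunoassay, with a stated time of 12 h, tested at 30 uM; a higher number here means more inhibition at the concentration tested (going by the name of the read-out), a lower number less inhibition: 47%
Compound 2, `COc1ccccc1C1CC(=O)c2ccccc2O1`, in this assay: 38.3%

Of the two measured compounds, compound 2 has the lower number, but the step of a number 8.7 percentage points lower from compound 1 to compound 2 (within the scatter) lies within the usual scatter, so the two results cannot be told apart with confidence.

Compound 3, `CCOc1ccccc1C1CC(=O)c2ccccc2O1`, has not yet been measured. The change from compound 2 is methyl in place of hydrogen on a saturated chain carbon bound to an oxygen on an aromatic ring. Among the compounds with values here, the one measured step, from compound 1 to compound 2, is the only step that bears on this change: it also altered the chain on the oxygen on the aromatic ring, and it stayed within the scatter. Adding a single carbon to that chain is therefore expected to give a step of a number 3.7 percentage points higher from compound 2 to compound 3 (within the scatter) that stays within the scatter as well, in no clear direction. For compound 3 the estimated value in this assay is 42%, with a range from 28% to 56%.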

Compound 3, a percentage reported as inhibition, at one concentration (the size of the read-out at that concentration, not a potency): 27.7%
Estimate against measurement, compound 3: 14.3 percentage points above; the whole stated range lies above it.
By their numbers in this assay, from the lowest: compound 3; then compounds 2 and 1 (each within the scatter of the next).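

In this assay, this position proves sensitive to a very small change: adding one methyl to the saturated chain carbon, which turns methoxy into ethoxy, gives a number 10.6 percentage points lower from compound 2 to compound 3 (beyond the scatter). Placing methyl rather than vinyl at the same carbon gives a number 19.3 percentage points lower from compound 1 to compound 3 (beyond the scatter), so the number does not simply follow the addition of carbon to this chain, and compound 1, which carries vinyl there, cannot be separated from compound 2, which carries hydrogen. No independent measurement is available to explain why methyl and vinyl differ here.

The compounds shown leave open how a longer saturated chain, such as propyl or butyl, would behave at this carbon. They also leave open whether a chain ending in an amine or a carboxylic acid would fit the same trend or break it.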